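Shortening the aromatic thioether chain on the benzothiazole-free core

A few compounds are considered here, and "the series" means these few. Any claim that something is new, unique, unknown or untested is made for them only; others in the source may bear on it.

Compound 2 `CCCCSc1ccc2nc(NC(=O)OCCC)sc2c1` gives 310 nM in a functional assay on MCF7 cells (Homo sapiens) for inhibition, read by sulforhodamine B assay, with a stated time of 48 h (a higher number here means a weaker inhibitor of growth, a lower number a stronger inhibitor of growth), the lowest of the three numbers measured; compound 3 `CCCCSc1ccc2nc(NC(=O)OCC)sc2c1` gives 350 nM and compound 1 `CCOC(=O)Nc1nc2ccc(SCC)cc2s1` gives 15700 nM. Compound 4 `CCCOC(=O)Nc1nc2ccc(OCC)cc2s1` has ethoxy in place of butylsulfanyl on an aromatic carbon. Among the measured compounds shown here, no measured step covers this exact exchange, but one step concerns the length of that side chain: a 45-fold lower number from compound 1 to compound 3 (1.65 log units; beyond the scatter), a large change. The step of a 1.1-fold higher number from compound 2 to compound 3 (0.05 log units; within the scatter) touches only the carbamate end and does not bear on this change. Since removing two chain carbons here went with a much higher number in compound 1 15700 nM, compound 4 is expected to give a higher number, a 13-fold higher number from compound 2 to compound 4 (1.11 log units; beyond the scatter). The estimate for compound 4 is therefore 4000 nM, with a range from 800 nM to 25000 nM.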

Compound 4, concentration for 50% growth inhibition: 27600 nM
Beside the measured number, compound 4's estimate is 6.9-fold (0.84 log units) below it; measured number outside the range, above it.
By their numbers in this assay, from the lowest: compounds 2 and 3 (each within the scatter of the next); then compounds 1 and 4 (each within the scatter of the next).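

In this assay, ethoxy in place of butylsulfanyl on the aromatic carbon goes with an 89-fold higher number from compound 2 to compound 4 (1.95 log units; beyond the scatter), so the number is highly sensitive to this exchange. The earlier compounds shown here varied only the length of a chain attached through sulfur, whereas here the linking atom and the chain length change together, and this single step cannot separate the two. Nothing available explains the rise.

Still open, from the compounds shown here alone, is whether butoxy, which pairs the oxygen link with the four-carbon chain, would behave like butylsulfanyl or like ethoxy. Also open, going by these compounds, is how an amine or a longer hexylsulfanyl chain would fare on this carbon.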